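From Phenyl to Cyano at a Saturated Chain Carbon

This account rests on a few compounds, and the source may have more. Where it says the series, first, only, none or still open, it means among the compounds named here.

Compound 1 `C#CCN(CC)Cc1cn(-c2cc(NC(=S)NCC)ncn2)cn1` and compound 2 `C#CCN(Cc1ccccc1)Cc1cn(-c2cc(NC(=S)NCC)ncn2)cn1` share one core and differ in a single place. In an assay on isolated protein for inhibition of Amine oxidase [flavin-containing] B (Homo sapiens), read by fluorescence and Amplex Red, with a stated time of 15 min, tested at 50 uM (on this read-out higher numbers stand for more inhibition at the one concentration tested (going by the name of the read-out) and lower numbers for less inhibition), compound 1 gives 35.1%, while compound 2 gives 18.4%. Within the data shown here, the step of a number 16.7 percentage points lower from compound 1 to compound 2 (beyond the scatter) leaves compound 2 with the lowest of the two numbers; its only neighbour is compound 1, whose number stands higher beyond the scatter. Compound 3 `C#CCN(CC#N)Cc1cn(-c2cc(NC(=S)NCC)ncn2)cn1` has not yet been measured in this assay. It differs from compound 2 thus: cyano in place of phenyl on a saturated chain carbon bound to an amine nitrogen. Among the measured compounds shown here, only one measured step bears on this change: the phenyl that now leaves is the same one whose arrival gave a number 16.7 percentage points lower from compound 1 to compound 2 (beyond the scatter), a modest fall. Its removal is therefore expected to bring the number back up, as a number 11.6 percentage points higher from compound 2 to compound 3 (beyond the scatter). Nothing measured tells how cyano itself behaves, so the range is wide. The estimate for compound 3 in this assay is 30%, between 12% and 50%.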

Compound 3, a percentage reported as inhibition, at one concentration (the size of the read-out at that concentration, not a potency): 15.4%
Compound 3: middle estimate off by 14.6 percentage points, on the high side; measured number inside the range.
By their numbers in this assay, from the lowest: compounds 3 and 2 (each within the scatter of the next); then compound 1.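

Putting cyano in place of phenyl on the saturated chain carbon bound to an amine nitrogen gives a number 3 percentage points lower from compound 2 to compound 3 (within the scatter) in this assay and does not restore the level of compound 1, so the aromatic ring alone does not set compound 2 apart from compound 1. Cyano in place of methyl gives a number 19.7 percentage points lower from compound 1 to compound 3 (beyond the scatter) and so points the same way as the phenyl step, which leaves compound 1, with its methyl, as the one of the three that stands apart. No measurement offered here explains why these groups read as they do.

On these data alone, it remains open whether a longer chain such as propyl, or a hydroxyl on this carbon, would stay with compound 1 or fall with compound 2 and compound 3. Each number also comes from one concentration, so the potency of these compounds stays open too.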